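Swapping 2-methoxyethyl for cyclooctyl: compound 2 to compound 4

This account rests on a few compounds, and the source may have more. Where it says the series, first, only, none or still open, it means among the compounds named here.

Measured in a functional assay on K562 cells (Homo sapiens) for antiproliferative activity, read by CellTiter-Glo, with a stated time of 72 h; on this read-out lower numbers stand for an effect already at smaller amounts and higher numbers for an effect only at larger amounts of compound:
- Compound 1 `CC(C)(C)CCNc1ncnc2c1ncn2[C@@H]1O[C@H](COS(N)(=O)=O)[C@@H](O)[C@H]1O`: 929 nM
- Compound 2 `COCCNc1ncnc2c1ncn2[C@@H]1O[C@H](COS(N)(=O)=O)[C@@H](O)[C@H]1O`: > 1000 nM
- Compound 3 `NS(=O)(=O)OC[C@H]1O[C@@H](n2cnc3c(NCC4CCCO4)ncnc32)[C@H](O)[C@@H]1O`: > 1000 nM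

Compound 2 stands at > 1000 nM, which is a limit and not a number. Compound 3 at > 1000 nM is also a limit. Compound 4 `NS(=O)(=O)OC[C@H]1O[C@@H](n2cnc3c(NC4CCCCCCC4)ncnc32)[C@H](O)[C@@H]1O` is still unmeasured, and it differs from compound 2 as follows: cyclooctyl in place of 2-methoxyethyl on a nitrogen on an aromatic ring. The nearest guides are an at least 1.0-fold higher number from compound 1 to compound 2 (0.03 log units; that floor lies within the scatter) and an at least 1.0-fold higher number from compound 1 to compound 3 (0.03 log units; that floor lies within the scatter), and both floors lie within the scatter, so they give only weak support. Only compound 1 has a true number, 929 nM, and its chain ends in tert-butyl, which like cyclooctyl has no oxygen. A modestly lower number is therefore expected, with the expected step being an at least 2.2-fold lower number from compound 2 to compound 4 (0.34 log units; beyond the scatter). For compound 4 the estimated value is 450 nM, with an expected range of 100 nM to 2000 nM.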

Compound 4, half-maximal effective concentration: 380 nM
For compound 4 the middle estimate is 1.2-fold (0.07 log units) above the measured one; measured number inside the range.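

In this assay, cyclooctyl on the nitrogen on the aromatic ring brings an at least 2.6-fold lower number from compound 2 to compound 4 (0.42 log units; beyond the scatter) and an at least 2.6-fold lower number from compound 3 to compound 4 (0.42 log units; beyond the scatter) as well. Both sizes are only floors, because compound 2 and compound 3 each sit at a limit: the limit of > 1000 nM in this assay, at which 2 of the 4 values shown sit. Cyclooctyl in place of 3,3-dimethylbutyl also brings a 2.4-fold lower number from compound 1 to compound 4 (0.39 log units; beyond the scatter) here, so the gain does not rest on limits alone.

On these data alone, whether the ring or simply the number of carbons matters stays open, and a straight octyl chain or a cyclohexyl group on this nitrogen would separate the two. As far as these compounds go, how an amine on the cyclooctyl ring would read is also open.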